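Shortening the Group on the Double-bonded Nitrogen

A few compounds are considered here, and "the series" means these few. Any claim that something is new, unique, unknown or untested is made for them only; others in the source may bear on it.

Three compounds have been measured in a functional assay (aorta) with Rattus norvegicus as the target; a higher number here means a weaker inhibitor, a lower number a stronger inhibitor:

compound 1, `CCC(C)(C)/N=C(\NC#N)Nc1cc(C(F)(F)F)cc(C(F)(F)F)c1`: 900 nM
compound 2, `C[C@H](/N=C(\NC#N)Nc1cc(Cl)cc(Cl)c1)c1ccccc1`: 30000 nM
compound 3, `C[C@@H](/N=C(\NC#N)Nc1cc(Cl)cc(Cl)c1)c1ccccc1`: 43800 nM

Compound 1 gives the lowest of the three numbers, and its distance to compound 2 and to compound 3 lies well beyond the scatter, so it is the strongest inhibitor of the set. Compound 4 is `CCC/N=C(\NC#N)Nc1cc(C(F)(F)F)cc(C(F)(F)F)c1`. It differs from compound 1 in one place: propyl in place of 1,1-dimethylpropyl on a double-bonded nitrogen. Going by the values given here, the only measured step, a 1.5-fold higher number from compound 2 to compound 3 (0.16 log units; within the scatter), concerns two compounds that share neither the group on the double-bonded nitrogen nor the ring substituents of compound 1, and it changes only the configuration as drawn, because of the fact that compounds 2 and 3 differ only in the configuration as drawn. Among the compounds with values here, it therefore says nothing about the change at hand, and no measured pair shows what replacing a 1,1-dimethylpropyl group with a propyl group does here. With no evidence to lean on, the expectation for compound 4 is worded loosely: a somewhat weaker inhibitor than compound 1 is expected, with the step of a 5.6-fold higher number from compound 1 to compound 4 (0.74 log units; beyond the scatter) carrying wide uncertainty. Compound 4 is estimated at 5000 nM, within a range from 1200 nM to 25000 nM.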

Compound 4, half-maximal inhibitory concentration: 12400 nM
Compound 4: the middle estimate sits 2.5-fold (0.39 log units) below what was measured, and the stated range covers the measured number.
By their numbers in this assay, from the lowest: compound 1; then compound 4; then compounds 2 and 3 (each within the scatter of the next).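

Replacing 1,1-dimethylpropyl with propyl on the double-bonded nitrogen gives a 14-fold higher number from compound 1 to compound 4 (1.14 log units; beyond the scatter) in this assay, so inhibition depends strongly on the group at this position, at least in this pair. The earlier step between compounds 2 and 3 changed only the configuration as drawn and stayed within the scatter, whereas this change, from 5 heavy atoms to 3 with no ring, hydrogen-bond donor, hydrogen-bond acceptor or charge involved, goes well beyond it. Nothing given here explains what lies behind this loss of strength.

Going by these compounds alone, with only two groups compared at this position, it remains open whether the loss follows chain length or branching, which an isopropyl, tert-butyl or butyl group could help separate. Going by these compounds, it is also open whether the same exchange would have a similar effect with the two chlorine substituents of compounds 2 and 3 on the ring.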